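Series notes: compound 3 to compound 4 in microsomal half-life

The source may report more compounds than this note shows. Statements on the series, on what has been measured and on what is new or still open speak of the compounds shown alone.

Compound 3 `NS(=O)(=O)c1cc(-c2nnc(/C=C/c3cccc(Cl)c3)o2)c(Cl)cc1SCc1ccccc1` gives 0.352 h in an ADME assay on microsomes from liver (Homo sapiens) for metabolic stability, read by LC-MS, using NADPH, tested at 5 uM (a lower number here means that the compound disappears faster, a higher number that the compound lasts longer), and on the numbers shown it stands within the scatter of both companions: the step of a 1.5-fold higher number from compound 1 to compound 3 (0.18 log units; within the scatter) from compound 1 `NS(=O)(=O)c1cc(-c2nnc(CCl)o2)c(Cl)cc1SCc1ccccc1` with 0.235 h, and the step of a 1.5-fold higher number from compound 2 to compound 3 (0.18 log units; within the scatter) from compound 2 `CC(C)(O)c1cn(Cc2nnc(-c3cc(S(N)(=O)=O)c(SCc4ccccc4)cc3Cl)o2)nn1` with 0.23 h. Compound 4 `NS(=O)(=O)c1cc(-c2nnc(/C=C/c3c(Cl)cccc3Cl)o2)c(Cl)cc1SCc1ccccc1` differs from compound 3 by 2,6-dichlorophenyl in place of 3-chlorophenyl on a double-bonded chain carbon bound to a double-bonded chain carbon. Among the measured compounds shown here, no measured step changes this phenyl; the steps that touch the ethenyl arm, a 1.5-fold higher number from compound 1 to compound 3 (0.18 log units; within the scatter) and a 1.5-fold higher number from compound 2 to compound 3 (0.18 log units; within the scatter), stayed within the scatter, and the step of a 1.0-fold lower number from compound 1 to compound 2 (0.01 log units; within the scatter) did too. The expectation for this assay is therefore no step beyond the scatter, a 1.0-fold lower number from compound 3 to compound 4 (0.00 log units; within the scatter). Compound 4 is estimated at 0.35 h, within 0.18 h to 0.7 h.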

Compound 4, half-life: 0.468 h
For compound 4 the middle estimate is 1.3-fold (0.13 log units) below the measured one, within the range that was stated.
By their numbers in this assay, from the lowest: compounds 2, 1, 3 and 4 (each within the scatter of the next, the first and the last beyond it).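

In this assay, 2,6-dichlorophenyl in place of 3-chlorophenyl on the ethenyl arm leaves the half-life unresolved from its predecessor (a 1.3-fold higher number from compound 3 to compound 4 (0.12 log units; within the scatter)). Among the compounds shown here, the 2-(2,6-dichlorophenyl)ethenyl arm gives the one step so far beyond the scatter when it replaces the triazole-bearing arm (a 2.0-fold higher number from compound 2 to compound 4 (0.31 log units; beyond the scatter)), whereas the step from chloromethyl stays within it (a 2.0-fold higher number from compound 1 to compound 4 (0.30 log units; within the scatter)). No evidence available here accounts for these numbers.

Open, from the compounds shown here alone, is whether an amine or a carboxylic acid on this phenyl, in place of chlorine, would shift the half-life beyond the scatter.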